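Replacing methyl with 1-bromoethyl in compound 2

A few compounds are considered here, and "the series" means these few. Any claim that something is new, unique, unknown or untested is made for them only; others in the source may bear on it.

- Compound 1 (`CCCCC(=O)N(Cc1ccc(OC)c(O)c1)c1cc(OC)c(OC)c(OC)c1`) with 66 nM
- Compound 2 (`COc1ccc(CN(C(C)=O)c2cc(OC)c(OC)c(OC)c2)cc1O`) with 79 nM

In a functional assay on MGC-803 cells (Homo sapiens) for inhibition, read by MTT assay, with a stated time of 48 h (on this read-out lower numbers stand for stronger inhibition and higher numbers for weaker inhibition), compound 2 gives 79 nM and stands level with compound 1 (66 nM), the two lying within the scatter of each other. Scatter here means the spread seen when the same measurement is repeated.

Compound 3 (`COc1ccc(CN(C(=O)C(C)Br)c2cc(OC)c(OC)c(OC)c2)cc1O`) has not been measured yet. It differs from compound 2 by one change (1-bromoethyl in place of methyl on a carbonyl carbon), which is 1-bromoethyl in place of methyl on a carbonyl carbon.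

Going by the values given here, one measured step bears on this (a 1.2-fold higher number from compound 1 to compound 2 (0.08 log units; within the scatter)), with hydrogen in place of propyl on a saturated chain carbon bound to a carbonyl carbon. That step stayed within the scatter, so no step beyond the scatter, in either direction, is expected in this assay for the new change. Among the compounds with values here, this expectation rests on a single step, and no measured compound carries a 1-bromoethyl group, so the range has to stay wide.

The expected change is slight (a 1.1-fold lower number from compound 2 to compound 3 (0.05 log units; within the scatter)), with no firm direction. For compound 3 the estimated value is 70 nM, with an expected range (20 nM to 250 nM).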

Compound 3, half-maximal inhibitory concentration: 120 nM
Compound 3: middle estimate off by 1.7-fold (0.23 log units), on the low side; the measured number falls inside the stated range.
By their numbers in this assay, from the lowest: compounds 1, 2 and 3 (each within the scatter of the next).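

In this assay, the group on the carbonyl carbon has now been varied three ways, and all three compounds lie within the scatter of one another. The step is a 1.5-fold higher number from compound 2 to compound 3 (0.18 log units; within the scatter) when 1-bromoethyl replaces methyl, and a 1.8-fold higher number from compound 1 to compound 3 (0.26 log units; within the scatter) when it replaces butyl, so methyl, butyl and 1-bromoethyl cannot be placed in any order on this read-out, and a group holding a bromine atom, with 3 heavy atoms against the 1 of methyl, is accepted at this position without a step beyond the scatter. Nothing at hand gives a measured reason for these numbers.

The compounds shown leave open whether the bromine atom itself counts for anything, since an isopropyl group, the same shape without bromine, would be needed to separate the atom from the branched chain. They also leave open how far this tolerance extends, for instance to an amine, a carboxylic acid or a phenyl ring on the same carbonyl carbon.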